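A few compounds are considered here, and "the series" means these few. Any claim that something is new, unique, unknown or untested is made for them only; others in the source may bear on it.

The series shares one core, carried by compound 1 `O=C(Nc1ccc(Cl)c(-c2nnc3c(Cl)cccn23)c1)c1ccc(C(F)(F)F)cc1F`, compound 2 `O=C(Nc1ccc(Cl)c(-c2nnc3c(Cl)cccn23)c1)c1ccccc1` and compound 3 `Cc1nc(C(=O)Nc2ccc(Cl)c(-c3nnc4c(Cl)cccn34)c2)cs1`, and differs only in the group on the carbonyl carbon of the amide. In a functional assay on T47D cells (Homo sapiens) for antiproliferative activity, read by MTT assay, with a stated time of 72 h (a lower number here means a stronger inhibitor, a higher number a weaker inhibitor), compound 1 gives 70800 nM. Compound 2 reaches only the limit of this assay, at > 100000 nM. Compound 3 likewise reaches only the limit, at > 100000 nM. Thus compound 3 stands at the edge of what this assay can read, together with compound 2, as the limit of > 100000 nM in this assay, at which 2 of the 3 values shown sit, shows. For the measured compounds named here, the one step between close neighbours, a step that the two limits leave unreadable from compound 2 to compound 3, cannot be sized.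

Compound 4 `O=C(Nc1ccc(Cl)c(-c2nnc3c(Cl)cccn23)c1)c1cccc(Cl)c1` differs from compound 3 in one place: 3-chlorophenyl in place of 2-methyl-1,3-thiazol-4-yl on a carbonyl carbon. Going by the values given here, no measured step bears directly on this change, since the step from compound 2 to compound 3 is unreadable. Compound 1, the only phenyl amide with a number, sits just below the limit, and compound 2 at it, so compound 4 is expected to stay near the limit, with an at least 1.1-fold lower number from compound 3 to compound 4 (0.04 log units; that floor lies within the scatter) reflecting that expectation. Compound 4 is estimated at 90000 nM, between 35000 nM and 250000 nM.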

Compound 4, half-maximal inhibitory concentration: 30200 nM
Estimate against measurement, compound 4: 3.0-fold (0.47 log units) above, and the stated range ends above it.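

In this assay, a change on this aromatic amide now gives a readable effect, which the unreadable step between the two limits could not: chloro in place of hydrogen on an aromatic carbon gives an at least 3.3-fold lower number from compound 2 to compound 4 (0.51 log units; beyond the scatter). Seen from the other neighbour, 3-chlorophenyl in place of 2-methyl-1,3-thiazol-4-yl on the carbonyl carbon gives an at least 3.3-fold lower number from compound 3 to compound 4 (0.51 log units; beyond the scatter). Both steps are floors and not full sizes, because each starts from a compound held at a limit of the assay: the limit of > 100000 nM in this assay, at which 2 of the 4 values shown sit.

On these data alone, the true size of either step therefore remains open. Also open, as far as these compounds go, is how a bromo group, a methoxy group or an amine would read in place of the chloro of the 3-chlorophenyl group.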